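The compounds below may be only part of what the source reports. "The series", "measured", "known", "first", "only" and "open" are said of these compounds alone.

Working notes on the series.

Compound 1 `NCCCOc1ccc(CNc2nc3ccc(Oc4ccc(O)cc4)cc3s2)cc1` is the starting point for the step followed here. In an assay on SH-SY5Y cells for inhibition of Voltage-dependent N-type calcium channel subunit alpha-1B (Homo sapiens), read by FLIPR and calcium flux, with stated times of 600 s and 300 s, in the presence of a further agent that is not named here (on this read-out higher numbers stand for weaker inhibition and lower numbers for stronger inhibition), compound 1 gives 205000 nM, the highest of the three numbers measured, although neither of its gaps to the other two compounds goes beyond the scatter. Compound 2 `CN(Cc1ccc(OCCCNC(=N)N)cc1)c1nc2ccc(Oc3ccccc3)cc2s1` gives 113000 nM in this assay, and compound 3 `CN(Cc1ccc(OCCCNC(=N)N)cc1)c1nc2ccc(Oc3cccc(C(F)(F)F)c3)cc2s1` gives 202000 nM. Within the data shown here, the one single-point step measured, a 1.8-fold higher number from compound 2 to compound 3 (0.25 log units; within the scatter), is the only comparison on record that touches the aryl ether.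

Compound 4 `NCCCOc1ccc(CNc2nc3ccc(Oc4cccc(C(F)(F)F)c4)cc3s2)cc1` differs from compound 1 by 3-(trifluoromethyl)phenyl in place of 4-hydroxyphenyl on an oxygen on an aromatic ring. Among the measured compounds shown here, the step from compound 2 to compound 3 bears on this change only in part: it introduces the same trifluoromethyl group, on a side chain that differs from that of compound 1, but it does not remove a hydroxyl, and no measured pair isolates the loss of that hydroxyl. With the trifluoromethyl part of the change being within the scatter and the hydroxyl part unmeasured, the expected step from compound 1 to compound 4 in this assay is small, a 1.2-fold higher number from compound 1 to compound 4 (0.09 log units; within the scatter), with no direction that the data can support beyond the scatter. Compound 4 is therefore estimated at 250000 nM in this assay, with a range of 100000 nM to 600000 nM.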

Compound 4, half-maximal inhibitory concentration: 144000 nM
Estimate against measurement, compound 4: 1.7-fold (0.24 log units) above, and the stated range covers the measured number.
By their numbers in this assay, from the lowest: compounds 2, 4, 3 and 1 (each within the scatter of the next).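

In this assay, among these compounds, the change on this oxygen on an aromatic ring, 3-(trifluoromethyl)phenyl in place of 4-hydroxyphenyl, gives a 1.4-fold lower number from compound 1 to compound 4 (0.15 log units; within the scatter) and is the first measured step in which the hydroxyl leaves. The entering group has more heavy atoms than the leaving one and carries no hydrogen-bond donor or acceptor, yet on the side chain of compound 1 this exchange stays within the scatter, so the read-out does not separate these two aryl groups at this position. No measurement at hand accounts for the size of this step.

The change from compound 1 to compound 4 alters the hydroxyl and the trifluoromethyl together, so the contribution of each on this side chain remains unresolved. Also open, from the compounds shown here alone, is whether any other group on this phenyl ring, such as a carboxylic acid or a dimethylamino group, or a longer chain in place of the aminopropoxy side chain, would move the number beyond the scatter.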